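The source may hold more compounds than are shown below. What is called first, only, known or untested is meant among the compounds shown, and "the series" means these compounds.

Compound 1 `Cc1cc(Nc2ccn(Cc3cccc4ccccc34)n2)n2nc(SCc3ccc(Br)cc3)nc2n1` gives 30000 nM in an ADME assay on GES1 cells (Homo sapiens) for inhibition, read by MTT assay, with a stated time of 72 h; a lower number here means a stronger inhibitor, a higher number a weaker inhibitor.
Compound 2 `Cc1ccc(CSc2nc3nc(C)cc(Nc4cc(-c5ccccc5)[nH]n4)n3n2)cc1` gives 36200 nM in the same assay.
Compound 3 `Cc1cc(Nc2cc(-c3ccccc3)[nH]n2)n2nc(SCc3cccc(Br)c3)nc2n1` gives only a limit of the assay, > 50000 nM.

Compound 2 stands next to compound 1, the two within the usual scatter of each other, while compound 3 reaches only a limit. Compound 4 `Cc1cc(Nc2cc(-c3ccccc3)[nH]n2)n2nc(SCc3nc4ccccc4[nH]3)nc2n1` differs from compound 2 in one place: 1H-benzimidazol-2-yl in place of 4-methylphenyl on a saturated chain carbon bound to a sulfur. Among the compounds with values here, the one measured step at the same place, an at least 1.3-fold higher number from compound 2 to compound 3 (0.14 log units; that floor lies within the scatter), ends at a limit of > 50000 nM in this assay, at which 1 of the 3 values shown sits, and shows no movement beyond the scatter. Compound 4 is therefore expected to stay close to compound 2, with a step of a 1.0-fold lower number from compound 2 to compound 4 (0.01 log units; within the scatter). Compound 4 is estimated at 35000 nM, between 15000 nM and 80000 nM.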

Compound 4, half-maximal inhibitory concentration: 27800 nM
Beside the measured number, compound 4's estimate is 1.3-fold (0.10 log units) above it; the measured number falls inside the stated range.
By their numbers in this assay, from the lowest: compounds 4, 1 and 2 (each within the scatter of the next). At a limit, above all of these: compound 3.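

At the saturated chain carbon bound to a sulfur, 1H-benzimidazol-2-yl is the only group shown with nitrogen in its rings and a hydrogen-bond donor, and in this assay it gives a 1.3-fold lower number from compound 2 to compound 4 (0.11 log units; within the scatter) in place of 4-methylphenyl. In place of 3-bromophenyl it gives an at least 1.7-fold lower number from compound 3 to compound 4 (0.25 log units; that floor lies within the scatter) and so shows no movement beyond the scatter either. Compound 3 reads > 50000 nM as a limit of the assay, not a number.

The compounds shown leave open whether an amine, a carboxylic acid or a longer chain at this place would move the number beyond the scatter.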